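Chloro in place of hydrogen on two cores

The compounds below may be only part of what the source reports. "The series", "measured", "known", "first", "only" and "open" are said of these compounds alone.

Measured in a functional assay on SH-SY5Y cells (Homo sapiens) for antiproliferative activity, read by MTT assay, with a stated time of 48 h; on this read-out lower numbers stand for stronger inhibition of growth and higher numbers for weaker inhibition of growth:
- compound 1 `COc1ccc(Cn2cnc3c(N(C)c4ccc(OC)cc4)ncnc32)cc1` gives 27000 nM
- compound 2 `COc1ccc(Cn2cnc3c(N(C)c4ccc(OC)cc4)nc(Cl)nc32)cc1` gives 31000 nM
- compound 3 `COc1ccc(Cn2cnc3c(Cl)ncnc32)cc1OC` gives only a limit, > 100000 nM

Compound 2 carries chloro in place of hydrogen on an aromatic carbon; the step is a 1.1-fold higher number from compound 1 to compound 2 (0.06 log units; within the scatter). The value of compound 3 is a limit and not a number, sitting at the limit of > 100000 nM in this assay, at which 1 of the 3 values shown sits. The difference between the core of compound 3 and the core of compound 1 is not broken down here. Compound 4 `COc1ccc(Cn2cnc3c(Cl)nc(Cl)nc32)cc1OC` is not yet measured and carries chloro in place of hydrogen on an aromatic carbon, the same kind of change as in compound 2, though here the place is meta to a chloro group (1 heavy atom) rather than meta to a large group. Because a 1.1-fold higher number from compound 1 to compound 2 (0.06 log units; within the scatter) sits within the scatter, the expected step is a number no higher from compound 3 to compound 4 (the limit leaves the size open). Compound 4 is therefore estimated at 100000 nM, between 40000 nM and 300000 nM, and may well again return only a limit.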

Compound 4, concentration for 50% growth inhibition: 5500 nM
For compound 4 the middle estimate is 18-fold (1.26 log units) above the measured one; measured number below the stated range.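

On the core of compound 3, chloro in place of hydrogen gives an at least 18-fold lower number from compound 3 to compound 4 (1.25 log units; beyond the scatter) in this assay. The same change therefore does not carry over with one size from one core to the other: the same change on two cores in this assay, a 1.1-fold higher number (0.06 log units; within the scatter) from compound 1 to compound 2 and an at least 18-fold lower number (1.25 log units; beyond the scatter) from compound 3 to compound 4, at least 20-fold (1.31 log units) apart, beyond the scatter of two such steps

Compound 3 gives only a limit, > 100000 nM, and not a number, and these compounds do not show which of the differences between the two cores decides the size of the step.

Still open, as far as these compounds go, is whether a bromo group or an amine in place of the same hydrogen on the core of compound 3 would give a step like that of chloro. Also open, from the compounds shown here alone, is whether any other core follows compound 4 or compound 2.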